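Swapping Methoxy for Fluoro: An Expected Cytotoxicity Value

A few compounds are considered here, and "the series" means these few. Any claim that something is new, unique, unknown or untested is made for them only; others in the source may bear on it.

Compound 1 `COc1cc(NC(=O)c2ccc(Cl)cc2)ccc1NS(C)(=O)=O` gives 70000 nM in an ADME assay on RAW264.7 cells (Mus musculus) for cytotoxicity, read by MTT assay, with a stated time of 48 h; a higher number here means a weaker inhibitor, a lower number a stronger inhibitor.
Compound 2 `COc1cc(NC(=O)c2ccc(C#N)cc2)ccc1NS(C)(=O)=O` reaches only a limit of this assay, namely > 250000 nM.
Compound 3 `CCS(=O)(=O)Nc1ccc(NC(=O)c2ccc(C#N)cc2)cc1OC` gives 66400 nM in this assay.

Compound 2 thus stands at a limit of this assay rather than at a number (the limit of > 250000 nM in this assay, at which 1 of the 3 values shown sits), so no firm value anchors it. Compound 4 `CS(=O)(=O)Nc1ccc(NC(=O)c2ccc(C#N)cc2)cc1F` differs from it by fluoro in place of methoxy on an aromatic carbon. Neither measured step touches this group: an at least 3.5-fold higher number from compound 1 to compound 2 (0.55 log units; beyond the scatter) concerns a different substituent, and an at least 3.7-fold lower number from compound 2 to compound 3 (0.57 log units; beyond the scatter) concerns the chain on the sulfonyl sulfur. Among the measured compounds shown here, with no step at the changed group, no shift beyond the scatter is expected, and an at least 1.2-fold lower number from compound 2 to compound 4 (0.09 log units; that floor lies within the scatter) is the estimated step. Compound 4 is therefore expected to give about 200000 nM in this assay, somewhere between 60000 nM and 700000 nM, with a real chance of another limit.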

Compound 4, half-maximal inhibitory concentration: > 250000 nM
Compound 4 was reported as a limit; the forecaster's own chance of this, stated with the estimate: 50%; middle value at least 1.2-fold (0.09 log units) from the limit.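

Compound 2 and compound 4 both sit at a limit in this assay, so no step between them can be read: the limit of > 250000 nM in this assay, at which 2 of the 4 values shown sit.

Going by these compounds, whether fluoro in place of methoxy shifts the number in this assay at all, and in which direction, stays open.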